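Working notes on the series: step from compound 2 to compound 4

A few compounds are considered here, and "the series" means these few. Any claim that something is new, unique, unknown or untested is made for them only; others in the source may bear on it.

Measured so far, in a functional assay on PC-12 cells (Rattus norvegicus) for cytotoxicity, read by MTT assay, with stated times of 2 h and 24 h, tested at 1 uM; a lower number here means a weaker effect, a higher number a stronger effect of the compound at the concentration tested:
- compound 1, `Cc1ccc(-n2nc(-c3ccc(C(F)(F)F)cc3O)nc2-c2ccccc2O)cc1`, gives 71.5%
- compound 2, `Oc1cc(C(F)(F)F)ccc1-c1nc(-c2ccccc2O)n(-c2ccc(F)cc2)n1`, gives 67.2%
- compound 3, `Oc1cc(C(F)(F)F)ccc1-c1nc(-c2ccccc2O)n(-c2ccc(OC(F)(F)F)cc2)n1`, gives 65.5%

Compound 2 stands second highest of these three numbers. Its nearest neighbour is compound 3, with a number 1.7 percentage points lower from compound 2 to compound 3 (within the scatter); its furthest is compound 1, with a number 4.3 percentage points lower from compound 1 to compound 2 (within the scatter). All three compounds therefore sit within the scatter of one another in this assay, and no order among them can be read from the numbers.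

Compound 4, `Oc1cc(C(F)(F)F)ccc1-c1nc(-c2ccccc2O)n(-c2ccccc2F)n1`, is not yet measured. It differs from compound 2 only by 2-fluorophenyl in place of 4-fluorophenyl on an aromatic nitrogen.

The measured steps all change which group is carried on the phenyl attached to the ring nitrogen: a number 4.3 percentage points lower from compound 1 to compound 2 (within the scatter), a number 6 percentage points lower from compound 1 to compound 3 (within the scatter) and a number 1.7 percentage points lower from compound 2 to compound 3 (within the scatter), each within the scatter. Within the data shown here, none of them moves a fluorine from one place on that phenyl to another, so the change to compound 4 has no direct precedent here. Because the three steps in this assay are all within the scatter, the expectation is no step beyond the scatter: a number 1.2 percentage points lower from compound 2 to compound 4 (within the scatter) is the estimated change.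

Compound 4 is therefore expected to give about 66% in this assay, with a range from 55% to 77%.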

Compound 4, a percentage reported as activity, at one concentration (the size of the read-out at that concentration, not a potency): 63.4%
For compound 4 the middle estimate is 2.6 percentage points above the measured one, and the stated range covers the measured number.
By their numbers in this assay, from the lowest: compounds 4, 3, 2 and 1 (each within the scatter of the next).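

Moving the fluorine from the 4-fluorophenyl to the 2-fluorophenyl arrangement on the aromatic nitrogen changes where a group sits on this phenyl, not which group it is, and in this assay this gives a number 3.8 percentage points lower from compound 2 to compound 4 (within the scatter). The two other changes at this position, a number 2.1 percentage points lower from compound 3 to compound 4 (within the scatter) and a number 8.1 percentage points lower from compound 1 to compound 4 (within the scatter), also stay within the scatter, so the four compounds cannot be placed in any order, and neither the identity nor this shift in place of the group shows a step beyond the scatter. No measurement is available that bears on an explanation of these numbers.

On these data alone, whether an amine or a carboxylic acid on this phenyl, or a longer chain in its place, would give a step beyond the scatter remains open. As far as these compounds go, the 2-hydroxyphenyl group is the same in all four compounds, so the result of replacing it also remains open.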